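This account rests on a few compounds, and the source may have more. Where it says the series, first, only, none or still open, it means among the compounds named here.

Series notes, a functional assay on HepG2 cells (Homo sapiens) for antiproliferative activity, read by CCK-8 assay, with a stated time of 48 h; a higher number here means a weaker inhibitor, a lower number a stronger inhibitor.
Compound 1 `CNC(=O)c1cc(Oc2ccc(/C=C/c3ccccn3)cc2)ccn1` gives 21600 nM.
Compound 2 `O=C(NCc1ccc(F)cc1)c1cc(Oc2ccc(/C=C/c3ccccn3)cc2)ccn1` gives 45100 nM.

Among the compounds with values here, compound 2 stands at the higher of the two numbers, compound 1 being its only neighbour; the one comparable step is a 2.1-fold higher number from compound 1 to compound 2 (0.32 log units; beyond the scatter), modest but beyond the scatter. Compound 3 `CC(C)NC(=O)c1cc(Oc2ccc(/C=C/c3ccccn3)cc2)ccn1` is the next member; its change from compound 2 is isopropyl in place of 4-fluorobenzyl on an amide-type nitrogen. Within the data shown here, no measured step covers this exchange directly. The step from compound 1 to compound 2 put 4-fluorobenzyl in place of hydrogen on this amide nitrogen and went with a weaker inhibitor; compound 3 takes that 4-fluorobenzyl away again and puts isopropyl there instead, so the earlier change is only partly kept. Compound 3 is therefore expected to fall between the two measured numbers, with the step of a 1.6-fold lower number from compound 2 to compound 3 (0.21 log units; within the scatter) expected to be small and toward a stronger inhibitor. The estimate for compound 3 is 28000 nM, range 12000 nM to 65000 nM.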

Compound 3, half-maximal inhibitory concentration: > 100000 nM
Compound 3: a limit, no number; the forecaster's own chance of this, stated with the estimate: 5%; middle value at least 3.5-fold (0.55 log units) away from the limit.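

Compound 3 in this assay is a limit of the assay and not a number: the limit of > 100000 nM in this assay, at which 1 of the 3 values shown sits. On this amide nitrogen, isopropyl in place of 4-fluorobenzyl goes with an at least 2.2-fold higher number from compound 2 to compound 3 (0.34 log units; beyond the scatter), and isopropyl in place of methyl goes with an at least 4.6-fold higher number from compound 1 to compound 3 (0.66 log units; beyond the scatter). Taken alone, a 2.1-fold higher number from compound 1 to compound 2 (0.32 log units; beyond the scatter) could be read as a larger group going with a weaker inhibitor, but compound 3 goes against that reading, since isopropyl has fewer heavy atoms than 4-fluorobenzyl and still stands at the weak end of the three.

Still open, on these data alone, is whether the branching of isopropyl goes with this step, which an unbranched ethyl or propyl chain on the same nitrogen could separate. Also open, as far as these compounds go, is how a primary amide, or a chain ending in an amine, reads at this position in this assay.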